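Para substituent swap: from nitro to chloro

A few compounds are considered here, and "the series" means these few. Any claim that something is new, unique, unknown or untested is made for them only; others in the source may bear on it.

Compound 1, `CC1=CC[C@@H]([C@@](C)(O)CCCC(C)(C)NC(=S)N/N=C\c2ccc(C)cc2)CC1`, gives 10100 nM in a functional assay on NCI-H460 cells (Homo sapiens) for cytotoxicity, read by sulforhodamine B assay; a higher number here means a weaker inhibitor of growth, a lower number a stronger inhibitor of growth.
Compound 2, `CC1=CC[C@@H]([C@@](C)(O)CCCC(C)(C)NC(=S)N/N=C\c2ccccc2[N+](=O)[O-])CC1`, gives 20600 nM.
Compound 3, `CC1=CC[C@@H]([C@@](C)(O)CCCC(C)(C)NC(=S)N/N=C\c2ccc([N+](=O)[O-])cc2)CC1`, gives 10100 nM.

Compound 3 stands level with compound 1 at the digits given, the two together being the lowest of the three numbers; compound 2 sits apart, as a 2.0-fold lower number from compound 2 to compound 3 (0.31 log units; beyond the scatter) shows. Compound 4, `CC1=CC[C@@H]([C@@](C)(O)CCCC(C)(C)NC(=S)N/N=C\c2ccc(Cl)cc2)CC1`, is the next member and has not yet been measured in this assay . It differs from compound 3 by chloro in place of nitro on an aromatic carbon.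

The step that bears most directly on this change is the one between the two para-substituted compounds, where no change at the digits printed from compound 1 to compound 3 (within the scatter). That exchange of one para group for another left the number untouched, so a further exchange at the same place is expected to behave alike. Among the compounds with values here, the only step beyond the scatter, a 2.0-fold higher number from compound 1 to compound 2 (0.31 log units; beyond the scatter), concerns a shift of the nitro group to another position rather than a change of group, and so says little here. For compound 4 the expected step is therefore a 1.0-fold lower number from compound 3 to compound 4 (0.00 log units; within the scatter), none beyond the scatter. Compound 4 is estimated at 10000 nM, in the range 5000 nM to 20000 nM.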

Compound 4, concentration for 50% growth inhibition: 8720 nM
Compound 4: middle estimate off by 1.1-fold (0.06 log units), on the high side; the measured number falls inside the stated range.
By their numbers in this assay, from the lowest: compounds 4, 1 and 3 (each within the scatter of the next); then compound 2.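

In this assay, nitro, methyl and chloro have now all been placed on this aromatic carbon, and the steps involving chloro stay within the scatter: a 1.2-fold lower number from compound 3 to compound 4 (0.06 log units; within the scatter), and a 1.2-fold lower number from compound 1 to compound 4 (0.06 log units; within the scatter). Replacing nitro, with its three heavy atoms and two hydrogen-bond acceptors, by chloro, with one heavy atom and no hydrogen-bond acceptors, therefore produces no step beyond the scatter, and the gap to the 2-nitrophenyl compound holds for 4-chlorophenyl as well: a 2.4-fold lower number from compound 2 to compound 4 (0.37 log units; beyond the scatter). No evidence is available on what lies behind these readings.

The compounds shown leave open whether an amine, a carboxylic acid or a hydroxyl on this same carbon would also stay within the scatter of these three groups, since all three tested so far give closely matching numbers. Within the data shown here, they also leave open whether the gap seen with 2-nitrophenyl belongs to that position generally or to nitro there alone, as compound 2 is the only member with its group placed differently.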